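Hydroxypyridinyl amides on a shared core: single-dose inhibition

A few compounds are considered here, and "the series" means these few. Any claim that something is new, unique, unknown or untested is made for them only; others in the source may bear on it.

Measured compounds:
compound 1, `CN1C(C(=O)Nc2ccc(O)cn2)=C(O)c2ccccc2S1(=O)=O`, 17%
compound 2, `CN1C(=O)c2ccccc2S1(=O)=O`, 12%

In a functional assay on the whole organism for inhibition, with Rattus norvegicus as the target, with a stated time of 4 h, at a dose of 33 mg/kg by the oral route (a higher number here means more inhibition at the dose given (going by the name of the read-out), a lower number less inhibition), compound 1 gives 17%. Compound 2, which lacks the carboxamide arm and the hydroxypyridinyl group on the shared core, gives 12% in this assay. The gap between the two values sits within the usual scatter of this read-out, so no ordering of compound 1 against compound 2 can be drawn from them; both show only modest inhibition at the dose used, and compound 1 is simply the one of the two whose number is not the lower.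

Compound 3, `CN1C(C(=O)Nc2cc(O)ccn2)=C(O)c2ccccc2S1(=O)=O`, has not been measured. It differs from compound 1 by 4-hydroxypyridin-2-yl in place of 5-hydroxypyridin-2-yl on an amide-type nitrogen. The two measured compounds give no indication of how the exchange of one hydroxypyridinyl group for the other would act. The step is therefore expected to stay within the scatter, with no clear direction: a number 2 percentage points lower from compound 1 to compound 3 (within the scatter). Compound 3 is expected to give 15% in this assay, with a range from 0% to 35%.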

Compound 3, a percentage reported as inhibition, in the whole organism at one dose (the size of the read-out at that dose, not a potency): 24%
Compound 3: the middle estimate sits 9 percentage points below what was measured; low and high end bracket the measured number.
By their numbers in this assay, from the lowest: compounds 2, 1 and 3 (each within the scatter of the next, the first and the last beyond it).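

In this assay, among the compounds shown here, the exchange of 5-hydroxypyridin-2-yl for 4-hydroxypyridin-2-yl on an amide-type nitrogen gives a number 7 percentage points higher from compound 1 to compound 3 (within the scatter) and is the first direct reading of a change at this place on the shared core. The two groups hold the same atoms, joined differently, and at this single oral dose the exchange does not separate compound 1 from compound 3, so neither group can be preferred over the other on these numbers. Nothing at hand on this pair offers an explanation of the step, so it stands as a bare observation.

The compounds shown leave open how a pyridinyl group carrying an amine or a methoxy group in place of the hydroxyl, or a plain phenyl group, would read on this amide-type nitrogen. They also leave open whether any exchange at this place reaches beyond the scatter of the read-out, as the one step shown stays within it.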